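The compounds below may be only part of what the source reports. "The series", "measured", "known", "first", "only" and "open" are said of these compounds alone.

In a functional assay (aorta) with Oryctolagus cuniculus as the target (a higher number here means weaker binding, a lower number tighter binding), compound 3 `COc1cc(C(C)=O)ccc1OCCCCN1CCC(C(c2ccc(F)cc2)c2ccc(F)cc2)CC1` gives 2.51 nM, the lowest of the three numbers in hand. Compound 2 `COc1cc(C(C)=O)ccc1OCCCN1CCC(CC(c2ccc(F)cc2)c2ccc(F)cc2)CC1` gives 3.16 nM, which lies within the scatter of compound 3, so no order between the two can be read. Compound 1 `COc1cc(C(C)=O)ccc1OCCCN1CCC(Cc2ccc(F)cc2)CC1` gives 20 nM, a gap from compound 3 that is beyond the scatter. Compound 4 `Fc1ccc(C(c2ccc(F)cc2)C2CCN(CCCCc3ccccc3)CC2)cc1` is not yet measured; its structure differs from compound 3 in one place: phenyl in place of 4-acetyl-2-methoxyphenoxy on a saturated chain carbon, four bonds along the chain from an amine nitrogen in a ring. Among the measured compounds shown here, no measured pair shows this change, so its effect has to be guessed. Compound 4 is expected to bind less tightly than compound 3, with the estimated step of a 4.8-fold higher number from compound 3 to compound 4 (0.68 log units; beyond the scatter) reaching beyond the scatter. For compound 4 the estimated value in this assay is 12 nM, with a range from 3 nM to 50 nM.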

Compound 4, dissociation constant: 2.51 nM
Beside the measured number, compound 4's estimate is 4.8-fold (0.68 log units) above it; the whole stated range lies above it.
By their numbers in this assay, from the lowest: compounds 3, 4 and 2 (each within the scatter of the next); then compound 1.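

In this assay, phenyl in place of 4-acetyl-2-methoxyphenoxy on a saturated chain carbon, four bonds along the chain from an amine nitrogen in a ring, gives no change at the digits printed from compound 3 to compound 4 (within the scatter). At this position, then, the number does not depend on the acetyl group, the methoxy group or the ring oxygen, at least when phenyl is the replacement. The earlier compounds shown here could not show this, since all of them carry 4-acetyl-2-methoxyphenoxy.

As far as these compounds go, it remains open whether a carboxylic acid, an amine or a pyridine ring at this place would hold the number as phenyl does. Nothing at hand offers a reason for the result.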